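This account rests on a few compounds, and the source may have more. Where it says the series, first, only, none or still open, it means among the compounds named here.

Compound 1 `COc1ccc(Oc2ccc(N3CC(=O)N([C@@H](CC4CCN(C(=O)C(C)C)CC4)c4nc5ccc(C)cc5n4C)C3=O)cc2)cc1`: > 100000 nM
Compound 2 `CC(C)C(=O)N1CCC(C[C@@H](c2nc3ccc(F)cc3n2C2CC2)N2C(=O)CN(c3ccc(Oc4ccc(F)cc4)cc3)C2=O)CC1`: > 100000 nM

In an ADME assay on Huh-7 cells (Homo sapiens) for cytotoxicity, read by MTT assay (a higher number here means a weaker inhibitor, a lower number a stronger inhibitor), compound 1 gives only a limit, > 100000 nM. Compound 2 also gives only a limit in this assay, > 100000 nM. Compound 2 thus stands at the limit of > 100000 nM in this assay, at which 2 of the 2 values shown sit, with no number of its own. Compound 3 `Cc1ccc2nc([C@H](CC3CCN(C(=O)C(C)C)CC3)N3C(=O)CN(c4ccc(Oc5ccc(F)cc5)cc4)C3=O)n(C3CC3)c2c1` differs from compound 2 by methyl in place of fluoro on an aromatic carbon. Within the data shown here, no step between measured compounds exists here, so in this assay no change beyond the usual scatter is expected, and the step that the limit leaves unreadable from compound 2 to compound 3 is estimated as essentially none. Compound 3 is therefore expected to give about 150000 nM in this assay, within 80000 nM to 400000 nM.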

Compound 3, half-maximal inhibitory concentration: > 100000 nM
Compound 3: no number, only a limit; the forecaster's own chance of this, stated with the estimate: 85%; the middle value is on the limit's open side.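

Compound 3, like compound 2, gives only a limit in this assay, so no step between them can be read: the limit of > 100000 nM in this assay, at which 3 of the 3 values shown sit.

The compounds shown leave open whether methyl in place of fluoro on an aromatic carbon changes anything in this assay.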